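This account rests on a few compounds, and the source may have more. Where it says the series, first, only, none or still open, it means among the compounds named here.

Measured so far in a physicochemical assay for lipophilicity, using the shake flask method, measured as octanol-water partition, at pH 7.4 (a lower number here means a more polar compound, a higher number a more lipophilic compound), are these compounds:
- compound 1 `CNC(=O)CN1CCC(c2cc3c(-c4ccc(=O)n(C(C)C)c4)ccnc3[nH]2)CC1` with 2.2
- compound 2 `CC(C)Cn1cc(-c2ccnc3[nH]c(C4CCN(CC(=O)N(C)C)CC4)cc23)ccc1=O` with 2

Compound 2 has the lower of these two numbers, but its gap to compound 1 lies within the usual scatter, so the two values cannot be told apart. The next compound to measure is compound 3 `CN(C)C(=O)CN1CCC(c2cc3c(-c4ccc(=O)n(C)c4)ccnc3[nH]2)CC1`, and the change from compound 2 is hydrogen in place of isopropyl on a saturated chain carbon bound to an aromatic nitrogen with hydrogen in place of isopropyl on a saturated chain carbon bound to an aromatic nitrogen. Cut one bond further out, this reads isobutyl to methyl. Among the compounds with values here, no measured pair shows this change, so the expectation rests on the structural change alone. A downward step in this assay is expected. The estimated size is a number 0.90 log units lower from compound 2 to compound 3 (beyond the scatter) and is expected to lie beyond the scatter. Compound 3 is estimated at 1.1 with an expected range from 0.7 to 1.5 for this measurement.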

Compound 3, distribution coefficient: 1.1
The estimate for compound 3 equals the measured number at the digits printed; low and high end bracket the measured number.
By their numbers in this assay, from the lowest: compound 3; then compounds 2 and 1 (each within the scatter of the next).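

In this assay the place on a saturated chain carbon bound to an aromatic nitrogen now has its first readable step: isobutyl to methyl, cut one bond further out, gives a number 0.90 log units lower from compound 2 to compound 3 (beyond the scatter) with the rest of the structure unchanged. Within the data shown here, the earlier pair differs in more than one place and its numbers cannot be told apart, so this single-place change is the first sign that the value responds to this position. Nothing measured here bears on the reason for this step.

A single step gives only the two ends of this change, leaving open how the value runs through an intermediate group such as ethyl. Also open, on these data alone, is whether a chain carrying a hydroxyl or an amine at this position would follow the same direction.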